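The compounds below may be only part of what the source reports. "The series", "measured", "known", "first", "only" and "open" are said of these compounds alone.

Measured in an assay on HEK293 cells for negative allosteric modulation of metabotropic glutamate receptor 5 (Homo sapiens), read by FLIPR, with a stated time of 1 h; on this read-out higher numbers stand for weaker inhibition and lower numbers for stronger inhibition:
compound 1, `O=C1c2sc(C#Cc3ccccc3)nc2CN1C1CC1`, gives 23 nM.
compound 2, `O=C(C1CCCC1)N1CCc2nc(C#Cc3ccccc3)sc2C1`, gives only > 10000 nM, which is a limit of the assay and not a number.

Compound 2 therefore stands at the limit of > 10000 nM in this assay, at which 1 of the 2 values shown sits, so its true value is known only as lying past that mark. Compound 3, `O=C(N1CCCC1)N1CCc2nc(C#Cc3ccccc3)sc2C1`, differs from compound 2 in one place: pyrrolidin-1-yl in place of cyclopentyl on a carbonyl carbon. Going by the values given here, no measured pair shows this change, so in this assay the step is expected to be small, neither clearly stronger nor clearly weaker beyond the usual scatter. For compound 3 the estimated value is 20000 nM, within a range from 4000 nM to 100000 nM. This amounts to an expected step that the limit leaves unreadable from compound 2 to compound 3.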

Compound 3, half-maximal inhibitory concentration: > 10000 nM
Compound 3 gave a limit, no number; the forecaster's own chance of this, stated with the estimate: 80%; the middle value lies beyond the limit too.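

Compound 2 and compound 3 each give only a limit of the assay and not a number, so no step between them can be read: the limit of > 10000 nM in this assay, at which 2 of the 3 values shown sit.

From the compounds shown here alone, what stays open is how far pyrrolidin-1-yl and cyclopentyl on a carbonyl carbon truly differ in compound 3 and compound 2.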